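Replacing the hydroxyethyl sulfonamide arm with a phenyl group

The source may hold more compounds than are shown below. What is called first, only, known or untested is meant among the compounds shown, and "the series" means these compounds.

Measured compounds:
Compound 1, `CC[C@@H]1C(=O)N(C)c2cnc(Nc3ccc(S(=O)(=O)NCCO)cc3)nc2N1C1CCCC1`: in a functional assay on NCI-H1975 cells (Homo sapiens) for antiproliferative activity, read by CCK-8 assay, with a stated time of 72 h (on this read-out lower numbers stand for stronger inhibition of growth and higher numbers for weaker inhibition of growth), compound 1 gives 2100 nM.
Compound 2, `CC[C@@H]1C(=O)N(C)c2cnc(-n3ccc4cc(C(=O)NC(C)C)ccc43)nc2N1C1CCCC1`: in this assay compound 2 gives 1840 nM.

Compound 1 stands as the higher of the two numbers shown, but compound 2 lies within the scatter of it, so the two cannot be ordered against each other. The unmeasured compound 3, `CC[C@@H]1C(=O)N(C)c2cnc(Nc3ccc(S(=O)(=O)Nc4ccccc4)cc3)nc2N1C1CCCC1`, keeps the core of compound 1 and differs from it in a single place: phenyl in place of 2-hydroxyethyl on a sulfonamide nitrogen. Among the measured compounds shown here, no step between measured compounds passes through this sulfonamide nitrogen, so the present numbers give nothing to fix either the size or the direction of such a change. The expected step is therefore a 1.4-fold lower number from compound 1 to compound 3 (0.15 log units; within the scatter), small and not clearly beyond the scatter in either direction. Compound 3 is estimated at 1500 nM in this assay, with a range from 400 nM to 6000 nM.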

Compound 3, concentration for 50% growth inhibition: 6000 nM
Estimate against measurement, compound 3: 4.0-fold (0.60 log units) below; low and high end bracket the measured number.
By their numbers in this assay, from the lowest: compounds 2 and 1 (each within the scatter of the next); then compound 3.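

The sulfonamide nitrogen proves to be a place where the group matters: in this assay, phenyl in place of 2-hydroxyethyl gives a 2.9-fold higher number from compound 1 to compound 3 (0.46 log units; beyond the scatter) and thus provides the first step through this nitrogen, modest in size but beyond the scatter. Growth inhibition weakens as a chain bearing a hydrogen-bond donor and acceptor gives way to an aromatic ring of carbon only, which has neither. Nothing available ties this loss to any particular feature of the exchange.

Going by these compounds, with only these two groups compared on this nitrogen, it remains open whether the weaker inhibition goes with the arrival of the phenyl ring or the departure of the hydroxyl. An ethyl chain or a benzyl group at the same place would help separate those two readings.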